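A few compounds are considered here, and "the series" means these few. Any claim that something is new, unique, unknown or untested is made for them only; others in the source may bear on it.

Measured compounds in a functional assay on MDA-MB-231 cells (Homo sapiens) for cytotoxicity, read by sulforhodamine B assay, with a stated time of 3 days; on this read-out lower numbers stand for stronger inhibition and higher numbers for weaker inhibition:
- compound 1, `O=[N+]([O-])c1ccccc1S(=O)(=O)N1CC(n2cnc3c(I)nc(Cl)nc32)OCc2ccccc21`: 256 nM
- compound 2, `O=[N+]([O-])c1ccccc1S(=O)(=O)N1CC(n2cnc3c(Cl)nc(Cl)nc32)OCc2ccccc21`: 280 nM

Compound 1 and compound 2 differ only in the halogen on the shared core, and the step of a 1.1-fold higher number from compound 1 to compound 2 (0.04 log units; within the scatter) leaves them indistinguishable in this assay. Among the compounds with values here, compound 2 therefore stands level with the single other measured compound, with no separation beyond the scatter.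

Compound 3, `O=S(=O)(c1ccccc1NO)N1CC(n2cnc3c(Cl)nc(Cl)nc32)OCc2ccccc21`, carries the change (hydroxyamino in place of nitro on an aromatic carbon). Within the data shown here, no measured step touches this part of the molecule: the only comparison available is the halogen swap from compound 1 to compound 2, which says nothing about the group on the six-membered aromatic ring of carbon only. The expectation for compound 3 in this assay rests on the structural change alone, with a wide range. A moderate loss is expected rather than a gain, but the measured series gives no support for either direction, so a step of a 2.1-fold higher number from compound 2 to compound 3 (0.33 log units; beyond the scatter) from compound 2 to compound 3 is estimated only loosely. Compound 3 is expected to give about 600 nM, with a plausible range from 150 nM to 2500 nM.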

Compound 3, half-maximal inhibitory concentration: 487 nM
For compound 3 the middle estimate is 1.2-fold (0.09 log units) above the measured one, within the range that was stated.
By their numbers in this assay, from the lowest: compounds 1, 2 and 3 (each within the scatter of the next).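

In this assay, the change from 2-nitrophenyl to 2-(hydroxyamino)phenyl gives a 1.7-fold higher number from compound 2 to compound 3 (0.24 log units; within the scatter), so the two groups cannot be told apart at this aromatic carbon, ortho to a large group. Within the data shown here, this is the first reading at this position, which the halogen swap on the shared core did not touch: the nitro group can give way to hydroxyamino, with its 2 hydrogen-bond donors against none for nitro, without a separation beyond the scatter in this cytotoxicity read-out. No measurement on hand accounts for this tolerance or connects it to any property of either group.

The compounds shown leave open how an amine or a carboxylic acid on the same aromatic carbon would read, and so whether this position tolerates change more broadly or only this one replacement. They also leave open whether hydroxyamino reads the same way with iodo in place of chloro on the shared core, since the group appears here only alongside the chloro core of compound 2.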